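Butoxy in place of acetyl on the shared core

This account rests on a few compounds, and the source may have more. Where it says the series, first, only, none or still open, it means among the compounds named here.

Compound 3 `CC(=O)c1cccc(N2C(N)=NC(N)=NC2(C)C)c1` gives 4.56 in a functional assay on L5178Y cells (Mus musculus) (a higher number here means a more potent compound, by a factor of ten per unit of this negative logarithm, a lower number a less potent compound), the second highest of the three numbers: compound 1 `CC1(C)N=C(N)N=C(N)N1c1cccc(C(O)c2ccccc2)c1` gives 4.17, and compound 2 `CCCCCCCCCCCCCOc1cccc(N2C(N)=NC(N)=NC2(C)C)c1` gives 6.52. Among the measured compounds shown here, the only measured step, a number 0.39 log units higher from compound 1 to compound 3 (beyond the scatter), is modest. Compound 4 `CCCCOc1cccc(N2C(N)=NC(N)=NC2(C)C)c1` differs from compound 3 by butoxy in place of acetyl on an aromatic carbon. For the measured compounds named here, no measured step follows an alkoxy entering for acetyl; the values of compound 2 and compound 3 show only that a much longer alkoxy chain goes with a far higher number, and butoxy is the shorter chain. An upward step is therefore expected, a number 0.84 log units higher from compound 3 to compound 4 (beyond the scatter), beyond the scatter yet well short of that gap. Compound 4 is estimated at 5.4, between 4.7 and 6.1.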

Compound 4, logarithm of the reciprocal of the active concentration, log(1/C): 5.95
Compound 4: middle estimate off by 0.55 log units, on the low side; the measured number falls inside the stated range.
By their numbers in this assay, from the lowest: compound 1; then compound 3; then compound 4; then compound 2.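

In this assay butoxy in place of acetyl gives a number 1.39 log units higher from compound 3 to compound 4 (beyond the scatter) on this aromatic carbon, so a chain far shorter than that of compound 2 already goes with a large rise. The longer chain still counts, with a number 0.57 log units lower from compound 2 to compound 4 (beyond the scatter) for hydrogen in place of nonyl, and butoxy also stands clear of hydroxy(phenyl)methyl, with a number 1.78 log units higher from compound 1 to compound 4 (beyond the scatter) at the same place. On these data alone, whether the chain oxygen matters stays open, as does the outcome for a plain butyl chain or an amine on this carbon. No measured evidence accounts for these steps.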